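The compounds below may be only part of what the source reports. "The series", "measured", "known", "first", "only" and "open" are said of these compounds alone.

Compound 1 `Cn1nc2c(=O)n(CC3(O)CCN(Cc4ccc(-c5ccco5)cc4Cl)CC3)cnc2c1-c1ccc(CNCCO)cc1` is the stronger of the two measured compounds in an assay on isolated protein for inhibition of ubiquitin carboxyl-terminal hydrolase 7 (Homo sapiens), with stated times of 30 min and 2 h (on this read-out higher numbers stand for weaker inhibition and lower numbers for stronger inhibition), where compound 1 gives 8.2 nM. Compound 2 `Cn1nc2c(=O)n(CC3(O)CCN(Cc4ccc(-n5cccn5)cc4Cl)CC3)cnc2c1-c1ccc(CN)cc1` is built differently in more than one place, and in this assay compound 2 gives 233 nM. The account now turns to compound 3 `Cn1nc2c(=O)n(CC3(O)CCN(Cc4ccc(-c5ccco5)cc4Cl)CC3)cnc2c1-c1ccc(CNC2CC2)cc1`, which is not yet measured. Compound 3 departs from compound 1 in one place: cyclopropyl in place of 2-hydroxyethyl on an amine nitrogen. For the measured compounds named here, with no measured pair to guide this exchange, the step of a 1.5-fold higher number from compound 1 to compound 3 (0.17 log units; within the scatter) is expected to stay within the scatter, in no settled direction. Compound 3 is therefore estimated at 12 nM, with a range from 4 nM to 40 nM.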

Compound 3, half-maximal inhibitory concentration: 54.1 nM
Beside the measured number, compound 3's estimate is 4.5-fold (0.65 log units) below it, and the stated range ends below it.
By their numbers in this assay, from the lowest: compound 1; then compound 3; then compound 2.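

Changing the group on this amine nitrogen from 2-hydroxyethyl to cyclopropyl matters in this assay and gives a 6.6-fold higher number from compound 1 to compound 3 (0.82 log units; beyond the scatter) with the rest of the molecule unchanged. The count of 3 heavy atoms stays the same, but the ring enters as the oxygen and its hydrogen-bond donor and acceptor leave, so this one exchange cannot separate those differences. Nothing at hand accounts for the step. As far as these compounds go, whether the oxygen or the ring matters remains open, and a plain ethyl or 2-methoxyethyl group on this nitrogen would bear on that.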